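From hydroxymethyl to fluoromethyl on the side chain

A few compounds are considered here, and "the series" means these few. Any claim that something is new, unique, unknown or untested is made for them only; others in the source may bear on it.

In a functional assay on HL-60 cells (Homo sapiens) for cytotoxicity, read by WST assay, with a stated time of 48 h (on this read-out higher numbers stand for weaker inhibition and lower numbers for stronger inhibition), compound 1 `COC[C@H](C)[C@@H](C)C(c1ccc(O)c(OC)c1)c1ccc(O)c(OC)c1` gives 68000 nM and compound 2 `COC[C@@H](C)[C@@H](C)C(c1ccc(O)c(OC)c1)c1ccc(O)c(OC)c1` gives 85000 nM, and the step of a 1.3-fold higher number from compound 1 to compound 2 (0.10 log units; within the scatter) stays within the scatter. Compound 3 `COc1cc(C(c2ccc(O)c(OC)c2)[C@H](C)[C@@H](C)CO)ccc1O` is recorded at > 100000 nM, which is a limit of the assay and not a number.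

Compound 4 `COc1cc(C(c2ccc(O)c(OC)c2)[C@H](C)[C@H](C)CF)ccc1O` carries 1-(fluoromethyl)ethyl in place of the 1-(hydroxymethyl)ethyl of compound 3, on a saturated chain carbon bound to two saturated chain carbons: 1-(fluoromethyl)ethyl in place of 1-(hydroxymethyl)ethyl on a saturated chain carbon bound to two saturated chain carbons.

Two measured steps change this same group: an at least 1.4-fold higher number from compound 1 to compound 3 (0.16 log units; that floor lies within the scatter) and an at least 1.1-fold higher number from compound 2 to compound 3 (0.07 log units; that floor lies within the scatter). Within the data shown here, both floors lie within the scatter, and no measured step involves fluorine. Compound 1 at 68000 nM and compound 2 at 85000 nM also lack the hydroxymethyl group, so a number near theirs is expected. A second limit remains possible for compound 4. The expected step is small and towards stronger inhibition, an at least 1.6-fold lower number from compound 3 to compound 4 (0.22 log units; that floor lies within the scatter). The estimated value for compound 4 is 60000 nM, within an expected range of 20000 nM to 120000 nM.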

Compound 4, half-maximal inhibitory concentration: 56000 nM
For compound 4 the middle estimate is 1.1-fold (0.03 log units) above the measured one, and the stated range covers the measured number.
By their numbers in this assay, from the lowest: compounds 4, 1 and 2 (each within the scatter of the next). At a limit, above all of these: compound 3.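

Setting 1-(fluoromethyl)ethyl in place of 1-(hydroxymethyl)ethyl on a saturated chain carbon bound to two saturated chain carbons gives an at least 1.7-fold lower number from compound 3 to compound 4 (0.25 log units; that floor lies within the scatter) in this assay. This floor is all that can be read from the step, because compound 3 stands at a limit of the assay and not at a number: the limit of > 100000 nM in this assay, at which 1 of the 4 values shown sits. Against the two methoxymethyl compounds the fluoromethyl compound cannot be told apart, with a 1.5-fold lower number from compound 2 to compound 4 (0.18 log units; within the scatter) and a 1.2-fold lower number from compound 1 to compound 4 (0.08 log units; within the scatter), so fluoro and methoxy read alike here in this assay.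

The compounds shown leave open whether any change at this place moves the number beyond the scatter. On these data alone, how an amine, a carboxylic acid or a longer chain in place of 1-(fluoromethyl)ethyl would read in this assay also remains open.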